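A few compounds are considered here, and "the series" means these few. Any claim that something is new, unique, unknown or untested is made for them only; others in the source may bear on it.

Three compounds share one core and differ only in the aryl group on a carbon with a double bond to nitrogen. Compound 1 `CN(C)CCn1cnnc1-c1cc(Oc2ccc(NC(=O)N/N=C/c3cccc(Cl)c3Cl)cc2F)ccn1` carries 2,3-dichlorophenyl there and in a functional assay on HT-29 cells (Homo sapiens) for cytotoxicity, read by MTT assay, with a stated time of 72 h (a lower number here means a stronger inhibitor, a higher number a weaker inhibitor), compound 1 gives 130 nM. Compound 2 `CN(C)CCn1cnnc1-c1cc(Oc2ccc(NC(=O)N/N=C/c3ccc(O)c(F)c3)cc2F)ccn1` carries 3-fluoro-4-hydroxyphenyl, and in this assay compound 2 gives 3310 nM. Compound 3 `CN(C)CCn1cnnc1-c1cc(Oc2ccc(NC(=O)N/N=C/c3ccc(O)cc3)cc2F)ccn1` carries 4-hydroxyphenyl, and in this assay compound 3 gives 1920 nM. Compound 3 thus stands second highest of the three numbers: the step of a 1.7-fold lower number from compound 2 to compound 3 (0.24 log units; within the scatter) lies within the scatter, while the step of a 15-fold higher number from compound 1 to compound 3 (1.17 log units; beyond the scatter) is large, as is a 25-fold higher number from compound 1 to compound 2 (1.41 log units; beyond the scatter).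

Compound 4 `CN(C)CCn1cnnc1-c1cc(Oc2ccc(NC(=O)N/N=C/c3ccccc3O[N+](=O)[O-])cc2F)ccn1` is the next member, not yet measured. It differs from compound 3 by 2-(nitrooxy)phenyl in place of 4-hydroxyphenyl on a carbon with a double bond to nitrogen. Going by the values given here, two measured steps bear on it: the step of a 15-fold higher number from compound 1 to compound 3 (1.17 log units; beyond the scatter) shows that leaving 4-hydroxyphenyl for a phenyl bearing halogens gave a much lower number, while a 1.7-fold lower number from compound 2 to compound 3 (0.24 log units; within the scatter) shows that a small change on the 4-hydroxyphenyl ring did not move the number beyond the scatter. Since the change to compound 4 removes the 4-hydroxyphenyl group altogether, a step toward a lower number is expected, of size a 3.8-fold lower number from compound 3 to compound 4 (0.58 log units; beyond the scatter). For compound 4 in this assay the expected value is 500 nM, with a range from 120 nM to 2000 nM.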

Compound 4, half-maximal inhibitory concentration: 950 nM
Compound 4: middle estimate off by 1.9-fold (0.28 log units), on the low side, and the stated range covers the measured number.
By their numbers in this assay, from the lowest: compound 1; then compound 4; then compounds 3 and 2 (each within the scatter of the next).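

The result shows that this position does not need halogens to give a lower number in this assay: 2-(nitrooxy)phenyl, which carries no halogen and no hydroxy group, gives a 2.0-fold lower number from compound 3 to compound 4 (0.31 log units; beyond the scatter) and a 3.5-fold lower number from compound 2 to compound 4 (0.54 log units; beyond the scatter). Halogens still give the lowest number among the four compounds, as 2,3-dichlorophenyl differs from 2-(nitrooxy)phenyl by a 7.3-fold higher number from compound 1 to compound 4 (0.86 log units; beyond the scatter), so removing the hydroxyphenyl group accounts for only part of the gain seen with compound 1. Among these four compounds, the two aryl groups without a hydroxy group give the lower numbers, with no exception, but no measurement here explains this ordering.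

In compound 4 the 4-hydroxyphenyl group is lost and the nitrooxy group is gained in a single change, so the shift in the number cannot be assigned to either event alone. A plain phenyl group at this place, or a phenyl bearing an amine or a carboxylic acid, would be needed to separate the two and to show whether the nitrooxy group itself matters.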